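The source may report more compounds than this note shows. Statements on the series, on what has been measured and on what is new or still open speak of the compounds shown alone.

Working notes on a small set of thiophene esters carrying two substituted phenyl rings.

Compound 1 `CCOC(=O)c1cc(-c2cc(OC)c(OC)c(OC)c2)c(-c2ccc(OC)cc2)s1` gives, in a functional assay on SGC-7901 cells (Homo sapiens) for antiproliferative activity, read by MTT assay, with a stated time of 72 h (a higher number here means a weaker inhibitor, a lower number a stronger inhibitor), a value of 9760 nM. Compound 2 `CCOC(=O)c1cc(-c2cc(OC)c(OC)c(OC)c2)c(-c2ccc(OC)c([N+](=O)[O-])c2)s1` carries one extra group on the 4-methoxyphenyl ring and in this assay compound 2 gives 18100 nM. The change between them, (nitro in place of hydrogen on an aromatic carbon), produced a 1.9-fold higher number from compound 1 to compound 2 (0.27 log units; within the scatter).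

Compound 3 `CCOC(=O)c1cc(-c2ccc(OC)cc2)c(-c2cc(OC)c(OC)c(OC)c2)s1` is built from the same atoms as compound 1, joined differently; the difference between the two cores is not broken down here. In this assay compound 3 gives 6820 nM. The values of compound 1 and compound 3 lie within the usual scatter of each other, so nothing is made of their order; compound 2 and compound 3 are separated by a gap beyond the scatter.

Compound 4 `CCOC(=O)c1cc(-c2ccc(OC)c([N+](=O)[O-])c2)c(-c2cc(OC)c(OC)c(OC)c2)s1` has not yet been measured in this assay. It differs from compound 3 by nitro in place of hydrogen on an aromatic carbon, the same change already seen from compound 1 to compound 2, at a place described in the same words. The expectation for compound 4 is a step of a 1.8-fold higher number from compound 3 to compound 4 (0.25 log units; within the scatter), resting on the earlier outcome because a 1.9-fold higher number from compound 1 to compound 2 (0.27 log units; within the scatter) came from the same change, made there on the core of compound 1 and here on the core of compound 3. The estimate for compound 4 in this assay is therefore 12000 nM, with the plausible range running from 5500 nM to 27000 nM. The measured number will show whether the core arrangement of compound 3 carries this change in the same way.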

Compound 4, half-maximal inhibitory concentration: 19400 nM
The estimate for compound 4 lay 1.6-fold (0.21 log units) below the measured number; the range from low to high includes it.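

In this assay, nitro in place of hydrogen on the 4-methoxyphenyl ring gives a 2.8-fold higher number from compound 3 to compound 4 (0.45 log units; beyond the scatter), so on this core the change stands clear of the scatter on its own, whereas the earlier step, a 1.9-fold higher number from compound 1 to compound 2 (0.27 log units; within the scatter), does not. Set side by side, the two steps cannot be told apart, and the change carries over between the two cores with no difference in size that can be claimed: the same change on two cores in this assay, a 1.9-fold higher number (0.27 log units; within the scatter) from compound 1 to compound 2 and a 2.8-fold higher number (0.45 log units; beyond the scatter) from compound 3 to compound 4, 1.5-fold (0.19 log units) apart, within the scatter of two such steps This shows only that, on these two cores, the nitro change moves the number the same way by a comparable amount; it does not show that one core responds more strongly than the other, and with only two pairs it gives no general rule for the series.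

The compounds shown leave open how an amine or a hydroxyl group would read at the same place on the ring, and whether the nitro step would hold if the ethyl ester gave way to a carboxylic acid or a longer chain. They also leave open whether the step seen here would hold outside this assay.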